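The source may report more compounds than this note shows. Statements on the series, on what has been measured and on what is new or still open speak of the compounds shown alone.

In a functional assay on KB403 cells (Homo sapiens) for cytotoxicity, read by MTT assay, with stated times of 6 h and 48 h (on this read-out higher numbers stand for weaker inhibition and lower numbers for stronger inhibition), compound 1 `Cn1c(-c2cc(-c3ccccc3)no2)cc(Br)c1Br` gives >= 100000 nM as a limit of the assay and not a number. Going by the values given here, compound 2 `Cn1c(-c2cc(-c3ccc[nH]3)no2)cc(Br)c1Br` gives 3100 nM as the only true number so far. Among the compounds with values here, the single measured step of an at least 32-fold lower number from compound 1 to compound 2 (1.50 log units; beyond the scatter) is large, its size resting on the limit of >= 100000 nM in this assay, at which 1 of the 2 values shown sits, and its change being 1H-pyrrol-2-yl in place of phenyl on an aromatic carbon. Compound 3 `Brc1cc(-c2cc(-c3ccc[nH]3)no2)[nH]c1Br` keeps that group and differs elsewhere: hydrogen in place of methyl on an aromatic nitrogen describes hydrogen in place of methyl on an aromatic nitrogen. The measured step of an at least 32-fold lower number from compound 1 to compound 2 (1.50 log units; beyond the scatter) lies at another place and so sets no size here, and no step beyond the scatter is expected in this assay for this change. The expected step of a 1.0-fold lower number from compound 2 to compound 3 (0.01 log units; within the scatter) is therefore small, though uncertain. Compound 3 is estimated at 3000 nM with an expected range from 800 nM to 12000 nM in this estimate.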

Compound 3, half-maximal inhibitory concentration: 4820 nM
Compound 3: the middle estimate sits 1.6-fold (0.21 log units) below what was measured; measured number inside the range.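

In this assay, the step of a 1.6-fold higher number from compound 2 to compound 3 (0.19 log units; within the scatter) shows that hydrogen can take the place of methyl on the aromatic nitrogen without a change that stands out from the scatter. Going by these compounds alone, the earlier compounds differed only at another place, so this is the first reading at this nitrogen, and it holds with the 1H-pyrrol-2-yl group kept in place. No measurement shown gives a reason for this result.

Whether an ethyl group, a benzyl group or a chain ending in an amine would read the same on this nitrogen stays open, as only methyl and hydrogen are shown there. Also open, on these data alone, is whether hydrogen in place of methyl would read the same on compound 1, which carries phenyl instead of 1H-pyrrol-2-yl.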